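A larger ring on the aromatic nitrogen

A few compounds are considered here, and "the series" means these few. Any claim that something is new, unique, unknown or untested is made for them only; others in the source may bear on it.

In a functional assay on MV4-11 cells (Homo sapiens) for inhibition, read by resazurin assay, with a stated time of 72 h (a lower number here means a stronger inhibitor of growth, a higher number a weaker inhibitor of growth), compound 1 (`CCn1cc(-c2ccnc(Nc3ccc(OC)cc3OC)n2)c2ccccc21`) gives 3590 nM and compound 2 (`COc1ccc(Nc2nccc(-c3sc(SC(C)C)nc3C)n2)c(OC)c1`) gives 5670 nM within the scatter of it, so these two share the top of the range. Compound 3 (`COc1ccc(Nc2nccc(-c3sc(SCCCN(C)C)nc3C)n2)c(OC)c1`) gives 370 nM as the lowest of the three numbers.

Compound 4 (`COc1ccc(Nc2nccc(-c3cn(C4CCCC4)c4ccccc34)n2)c(OC)c1`) differs from compound 1 in one place, with cyclopentyl in place of ethyl on an aromatic nitrogen and nothing else changed. Among the compounds with values here, the one measured step, a 15-fold lower number from compound 2 to compound 3 (1.19 log units; beyond the scatter) on a sulfur, is large, but it lies at another place and on another core and gives no measure for this change. Within the data shown here, no measured step touches the group on the aromatic nitrogen, so no shift beyond the scatter is expected. In this assay the expected step is a 1.2-fold lower number from compound 1 to compound 4 (0.08 log units; within the scatter) and nothing in the data argues for a larger one. For compound 4 the estimated value is 3000 nM with an expected range from 1000 nM to 9000 nM in this read-out.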

Compound 4, concentration for 50% growth inhibition: 1740 nM
Compound 4: the middle estimate sits 1.7-fold (0.24 log units) above what was measured; the measured number falls inside the stated range.
By their numbers in this assay, from the lowest: compound 3; then compound 4; then compounds 1 and 2 (each within the scatter of the next).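

In this assay, within the data shown here, the group on the aromatic nitrogen proves able to move the number: cyclopentyl in place of ethyl gives a 2.1-fold lower number from compound 1 to compound 4 (0.31 log units; beyond the scatter) and is the first measured step at this position, modest in size. The entering group brings only carbon and one five-membered non-aromatic ring, with no hydrogen-bond donors or acceptors and no net charge, so the step comes from a change of that kind alone. Nothing among the data available accounts for the step.

The compounds shown leave open whether the trend continues with a cyclohexyl ring on this nitrogen or reverses there. They also leave open how a chain ending in a piperidine amine would behave at this position on the core of compound 1.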